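From Methyl to Fluoro at a Measurement Limit

The source may hold more compounds than are shown below. What is called first, only, known or untested is meant among the compounds shown, and "the series" means these compounds.

In a functional assay on Huh-7 cells (Homo sapiens) for cytotoxicity, read by MTT assay, with a stated time of 72 h (on this read-out higher numbers stand for lower toxicity in this test and lower numbers for higher toxicity in this test), compound 1 `CS(=O)(=O)N1CCC2(CC1)OOC1(CCCCC1)OO2` gives > 100 ug/mL, which is a limit. Compound 2 `CCCS(=O)(=O)N1CCC2(CC1)OOC1(CCCCC1)OO2` gives > 100 ug/mL, also a limit. Compound 3 `Cc1ccc(S(=O)(=O)N2CCC3(CC2)OOC2(CCCCC2)OO3)cc1` gives > 100 ug/mL, again a limit rather than an exact number. Among the measured compounds shown here, the series so far therefore rests on (the limit of > 100 ug/mL in this assay, at which 3 of the 3 values shown sit).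

Compound 4 `O=S(=O)(c1ccc(F)cc1)N1CCC2(CC1)OOC1(CCCCC1)OO2` differs from compound 3 by one change: fluoro in place of methyl on an aromatic carbon. The nearest measured changes are a step that the two limits leave unreadable from compound 1 to compound 3 and a step that the two limits leave unreadable from compound 2 to compound 3. Neither points in a direction, so no change beyond the usual scatter is expected. The expected change is a step that the limit leaves unreadable from compound 3 to compound 4. For compound 4 the estimate is 130 ug/mL, with an expected range of 70 ug/mL to 300 ug/mL.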

Compound 4, half-maximal cytotoxic concentration: > 100 ug/mL
Compound 4: no number, only a limit (the forecaster's own chance of this, stated with the estimate: 80%); the middle value is on the limit's open side.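

Compound 4 gives only a limit in this assay, as do compound 1, compound 2 and compound 3, so none of its steps to them can be read: the limit of > 100 ug/mL in this assay, at which 4 of the 4 values shown sit.

Whether fluoro in place of methyl, or any other change among these compounds, alters the read-out in this assay stays open.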